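From 4-methylphenyl to 4-methoxyphenyl: no clear step expected

The source may report more compounds than this note shows. Statements on the series, on what has been measured and on what is new or still open speak of the compounds shown alone.

In a functional assay on PANC-1 cells (Homo sapiens) for inhibition, read by MTT assay, with a stated time of 24 h (a higher number here means a weaker inhibitor, a lower number a stronger inhibitor), compound 1 `CC1(C)[C@H]2CC[C@]1(C)N(Cc1cn(-c3ccccc3C#N)nn1)C(=O)C2` gives 240 nM and compound 2 `CC1(C)[C@H]2CC[C@]1(C)N(Cc1cn(-c3ccccc3)nn1)C(=O)C2` gives 160 nM while compound 3 `Cc1ccc(-n2cc(CN3C(=O)C[C@@H]4CC[C@@]3(C)C4(C)C)nn2)cc1` gives 270 nM and so sits within the scatter of both. Compound 4 `COc1ccc(-n2cc(CN3C(=O)C[C@@H]4CC[C@@]3(C)C4(C)C)nn2)cc1` differs from compound 3 methoxy in place of methyl on an aromatic carbon by methoxy in place of methyl on an aromatic carbon, para to a large group. Among the compounds with values here, three measured steps bear on it: a 1.7-fold higher number from compound 2 to compound 3 (0.23 log units; within the scatter) for methyl in place of hydrogen, a 1.1-fold higher number from compound 1 to compound 3 (0.05 log units; within the scatter) for 4-methylphenyl in place of 2-cyanophenyl and a 1.5-fold lower number from compound 1 to compound 2 (0.18 log units; within the scatter) for hydrogen in place of cyano. All stayed within the scatter, so no step beyond it is expected here. The estimated change is a 1.1-fold lower number from compound 3 to compound 4 (0.03 log units; within the scatter) and lies within the scatter. Compound 4 is expected at 250 nM within a range of 130 nM to 470 nM on this reading.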

Compound 4, half-maximal inhibitory concentration: 330 nM
Compound 4: the middle estimate sits 1.3-fold (0.12 log units) below what was measured; low and high end bracket the measured number.
By their numbers in this assay, from the lowest: compounds 2, 1, 3 and 4 (each within the scatter of the next, the first and the last beyond it).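

In this assay, methoxy on an aromatic carbon, para to a large group, stays within the scatter of methyl (a 1.2-fold higher number from compound 3 to compound 4 (0.09 log units; within the scatter)), and 4-methoxyphenyl stays within the scatter of 2-cyanophenyl (a 1.4-fold higher number from compound 1 to compound 4 (0.14 log units; within the scatter)). Methoxy in place of hydrogen gives the first step in this set beyond the scatter, though only a modest one (a 2.1-fold higher number from compound 2 to compound 4 (0.31 log units; beyond the scatter)). No evidence given here explains that step. Going by these compounds, it remains open whether an amine, a carboxylic acid or a longer chain such as butoxy at this carbon would move the number beyond the scatter of compound 3.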